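Substituent change at the aryl end of the shared core

The source may hold more compounds than are shown below. What is called first, only, known or untested is meant among the compounds shown, and "the series" means these compounds.

Two compounds of the series have a number in a functional assay on M21 cells (Homo sapiens) for antiproliferative activity, read by sulforhodamine B assay, with a stated time of 48 h; on this read-out higher numbers stand for weaker inhibition of growth and lower numbers for stronger inhibition of growth. Compound 1 `CCCCc1ccc(-c2cc(N3CCC(CCNS(N)(=O)=O)CC3)ncn2)cc1` gives 15100 nM. Compound 2 `CC(C)(C)c1ccc(-c2cc(N3CCC(CCNS(N)(=O)=O)CC3)ncn2)cc1` gives 18400 nM. Going by the values given here, the only step between measured compounds is a 1.2-fold higher number from compound 1 to compound 2 (0.09 log units; within the scatter), so nothing beyond the scatter separates the two; compound 2 has the highest of the two numbers, but its nearest neighbour, compound 1, lies within the scatter of it, and no order can be read from this pair.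

Compound 3 `CCOC(=O)c1ccc(-c2cc(N3CCC(CCNS(N)(=O)=O)CC3)ncn2)cc1` is the next member. Its change from compound 2 is ethoxycarbonyl in place of tert-butyl on an aromatic carbon. Among the compounds with values here, no measured step bears directly on this change: the one step recorded swaps one alkyl group for another on the same aromatic carbon and stays within the scatter, whereas here an alkyl group gives way to ethoxycarbonyl. Within the data shown here, with no step to lean on, the expectation is that the number for compound 3 stays close to those of compound 1 and compound 2, with a wide range to allow for either direction. The estimated step is a 1.1-fold higher number from compound 2 to compound 3 (0.04 log units; within the scatter). Compound 3 is estimated at 20000 nM, in a range from 6000 nM to 65000 nM.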

Compound 3, concentration for 50% growth inhibition: 9000 nM
For compound 3 the middle estimate is 2.2-fold (0.35 log units) above the measured one; measured number inside the range.
By their numbers in this assay, from the lowest: compounds 3, 1 and 2 (each within the scatter of the next, the first and the last beyond it).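

In this assay, going by these compounds alone, the step of a 2.0-fold lower number from compound 2 to compound 3 (0.31 log units; beyond the scatter) is modest, but it is the first at this position to lie beyond the scatter, so the group on this aromatic carbon, para to a large group, can shift the number, which the alkyl pair alone did not show. The same replacement starting from butyl gives a 1.7-fold lower number from compound 1 to compound 3 (0.22 log units; within the scatter) and stays within the scatter, so ethoxycarbonyl is separated from tert-butyl but not from butyl, and the shift depends on which alkyl group is taken as the reference. Ethoxycarbonyl differs from both alkyl groups in carrying hydrogen-bond acceptors and a double bond outside aromatic rings, but no available evidence connects either feature to the lower number.

The compounds shown leave open whether the ester is needed at this position or whether a carboxylic acid, a primary amide or an amine would give a similar number or a lower one. They also do not show whether a longer ester chain or a small group such as fluorine would move the number further from that of compound 2.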